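Opening the Amide Ring in a Serotonin Receptor Binding Series

The source may report more compounds than this note shows. Statements on the series, on what has been measured and on what is new or still open speak of the compounds shown alone.

Among the measured compounds shown here, compound 2 `CC(C)c1ccccc1N1CCN(CCCCCC(=O)N2CCc3ccccc3C2)CC1` is one of two compounds measured in an assay on HEK293 cells for displacement of a labelled ligand from 5-hydroxytryptamine receptor 7 (Rattus norvegicus) (a lower number here means a stronger inhibitor, a higher number a weaker inhibitor), where compound 2 gives 6 nM. Compound 1 `O=C(CCCCCN1CCN(c2ccccc2-c2ccccc2)CC1)N1CCc2ccccc2C1` gives 3.81 nM in this assay, and the step of a 1.6-fold higher number from compound 1 to compound 2 (0.20 log units; within the scatter) leaves the two within the scatter of each other. Compound 3 `CC(C)c1ccccc1N1CCN(CCCCCC(=O)NCc2ccc(C#N)cc2)CC1` has not yet been measured; it differs from compound 2 by (4-cyanobenzyl)amino in place of 1,2,3,4-tetrahydroisoquinolin-2-yl on a carbonyl carbon. For the measured compounds named here, the only measured step, a 1.6-fold higher number from compound 1 to compound 2 (0.20 log units; within the scatter), concerns a different part of the molecule; no measured step bears on this change. Without such a guide, a modest weakening is expected, a 2.5-fold higher number from compound 2 to compound 3 (0.40 log units; beyond the scatter), with a wide range. Compound 3 is therefore estimated at 15 nM, between 4 nM and 60 nM.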

Compound 3, inhibition constant: 8.6 nM
The estimate for compound 3 lay 1.7-fold (0.24 log units) above the measured number; measured number inside the range.
By their numbers in this assay, from the lowest: compounds 1, 2 and 3 (each within the scatter of the next, the first and the last beyond it).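

On the carbonyl carbon, putting (4-cyanobenzyl)amino in place of 1,2,3,4-tetrahydroisoquinolin-2-yl gives a 1.4-fold higher number from compound 2 to compound 3 (0.16 log units; within the scatter) in this assay. This position therefore accepts a group with one ring fewer, plus a nitrile and an amide hydrogen, without a change beyond the scatter. Nothing available explains this result.

On these data alone, what the nitrile and the amide hydrogen each contribute remains open; benzylamino and benzyl(methyl)amino on the same carbonyl carbon would separate them. As far as these compounds go, whether the same change behaves alike on the core of compound 1 is also open.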